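This account rests on a few compounds, and the source may have more. Where it says the series, first, only, none or still open, it means among the compounds named here.

Measured in an assay on isolated protein for inhibition of DNA topoisomerase 1 (Homo sapiens), with a stated time of 30 min, tested at 100 uM; on this read-out lower numbers stand for a weaker effect and higher numbers for a stronger effect at the one concentration tested:

compound 1, `COc1ccc(-c2cc3ccccc3c(-c3ccc(O)cc3)n2)cc1`, gives 6.7%
compound 2, `COc1ccc(-c2cc3ccccc3c(-c3ccc(OC)cc3)n2)cc1`, gives 0%
compound 3, `COc1cc(OC)cc(-c2cc3ccccc3c(-c3cccc(O)c3)n2)c1`, gives 0%

All three numbers sit low, and compound 3 is level with compound 2 at the digits shown. Compound 1 and compound 2 differ in one place, (methyl in place of hydrogen on an oxygen on an aromatic ring), and the step from the first to the second is a number 6.7 percentage points lower from compound 1 to compound 2 (within the scatter).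

Compound 4, `COc1cc(OC)cc(-c2cc3ccccc3c(-c3cccc(OC)c3)n2)c1`, has not been measured. It differs from compound 3 in the same place by the same change, (methyl in place of hydrogen on an oxygen on an aromatic ring), which appears twice among these compounds. The difference between the core of compound 3 and the core of compound 1 is not broken down here.

In this assay the step from compound 3 to compound 4 is expected to be no change at the digits printed from compound 3 to compound 4 (within the scatter), beside the earlier step of a number 6.7 percentage points lower from compound 1 to compound 2 (within the scatter), because compound 3 already gives 0% and the measured step of this change stayed within the scatter. For compound 4 the estimate is 0%, with a likely range from 0% to 8%.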

Compound 4, a percentage reported as inhibition, at one concentration (the size of the read-out at that concentration, not a potency): 0%
The estimate for compound 4 equals the measured number at the digits printed; low and high end bracket the measured number.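

In this assay, replacing hydroxy with methoxy on the core of compound 3 gives no change at the digits printed from compound 3 to compound 4 (within the scatter), and this step does not differ from the step for the same change on the other core: the same change on two cores in this assay, a number 6.7 percentage points lower (within the scatter) from compound 1 to compound 2 and no change at the digits printed (within the scatter) from compound 3 to compound 4, 6.7 percentage points apart, within the scatter of two such steps. For the compounds shown here, on these two cores, then, the change gives no step that stands out from the scatter, and its outcome carries over from one core to the other as far as these numbers can tell. This does not show that the change is harmless or without effect in general: all four numbers sit low, so a real loss would have little room to appear, and two cores are a small sample.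

On these data alone, it remains open how the same change behaves on a core whose hydroxy compound gives a clearly higher number. As far as these compounds go, it is also open whether another group in this place, such as an amine, a carboxylic acid or a longer chain, would lift the number clear of the scatter.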